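Sulfonamide replaced by methoxy on the pendant aryl ring

This account rests on a few compounds, and the source may have more. Where it says the series, first, only, none or still open, it means among the compounds named here.

Measured so far:
compound 1, `CCCCCCCCCCCCOc1ccc(COc2cccc(C(=O)O)c2)nc1/C=C/C(=O)O`: 1130 nM
compound 2, `COc1ccc(CCCCCCCCOc2ccc(C[S+]([O-])c3cccc(NS(=O)(=O)c4ccccc4)c3)nc2/C=C/C(=O)O)cc1`: 147 nM
compound 3, `COc1ccc(CCCCCCOc2ccc(CC(O)c3cccc(C(=O)O)c3)nc2/C=C/C(=O)O)cc1`: 165 nM

In an assay for binding affinity to leukotriene B4 receptor 1 (Homo sapiens) (a higher number here means a weaker inhibitor, a lower number a stronger inhibitor), compound 2 gives the lowest number of the three; compound 3 lies within the scatter of it, compound 1 lies beyond it. Compound 4, `COc1ccc(CCCCCCCCOc2ccc(C[S+]([O-])c3cccc(OC)c3)nc2/C=C/C(=O)O)cc1`, is not yet measured. It differs from compound 2 in one place: methoxy in place of (phenylsulfonyl)amino on an aromatic carbon. For the measured compounds named here, no pair of measured compounds differs by this change alone, so the size of the step is not anchored by data. Both measured compounds carrying a larger substituted ring at this end, compound 2 at 147 nM and compound 3 at 165 nM, sit well below compound 1. Trimming to methoxy is expected to raise the number, by an estimated 3.1-fold higher number from compound 2 to compound 4 (0.49 log units; beyond the scatter). Compound 4 is expected near 450 nM, range 130 nM to 1600 nM.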

Compound 4, inhibition constant: 232 nM
Estimate against measurement, compound 4: 1.9-fold (0.29 log units) above, within the range that was stated.
By their numbers in this assay, from the lowest: compounds 2, 3 and 4 (each within the scatter of the next); then compound 1.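

In this assay methoxy in place of (phenylsulfonyl)amino on this aromatic carbon gives a 1.6-fold higher number from compound 2 to compound 4 (0.20 log units; within the scatter) and no step beyond that. For this pair, the six-membered aromatic ring and the hydrogen-bond donor of (phenylsulfonyl)amino are therefore not required for a number in this range. No measured data are at hand that bear on the origin of this result.

Still open, from the compounds shown here alone, is whether a smaller group such as hydroxyl or an amine on this aromatic carbon gives a number in the same range. Also open, going by these compounds, is whether a larger group, such as benzyloxy, does.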